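Thiazolyl in place of fluorophenyl: cytotoxicity expectation

The source may hold more compounds than are shown below. What is called first, only, known or untested is meant among the compounds shown, and "the series" means these compounds.

In a toxicity assay on HepG2 2.2.15 cells (Homo sapiens) for cytotoxicity, read by CCK-8 assay, with a stated time of 8 days (on this read-out higher numbers stand for lower toxicity in this test and lower numbers for higher toxicity in this test), compound 1 `CC(C)Cc1nn(-c2cccc(F)c2)cc1C(=O)NCc1ccc(F)cc1` returns only a limit, > 100000 nM. Compound 2 `CCOC(=O)c1cn(-c2ccccc2F)nc1CC(C)C` also returns a limit in this assay, > 100000 nM. Among the compounds with values here, compound 3 `CCOC(=O)c1cn(-c2cccc(C(=O)O)c2)nc1CC(C)C` is the one member of the set with a number in this assay, 7100 nM. Compound 1 therefore stands where most of the measured set stands: the limit of > 100000 nM in this assay, at which 2 of the 3 values shown sit. Within the data shown here, no two measured compounds differ in a single place, so no measured step is available; compound 2 and compound 3 show only that one returns a limit and the other a number.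

Compound 4 `CC(C)Cc1nn(-c2nccs2)cc1C(=O)NCc1ccc(F)cc1` has not been measured in this assay. It differs from compound 1 in one place: 1,3-thiazol-2-yl in place of 3-fluorophenyl on an aromatic nitrogen. The change is small in atom count, as the counted difference shows, and nothing in the measured set speaks against the new compound staying at the limit region. Among the measured compounds shown here, the step of a number no higher from compound 1 to compound 4 (the limit leaves the size open) is expected to be none beyond the scatter, since compound 1 sits at > 100000 nM and the set gives no measured step to suggest otherwise. Compound 4 is accordingly expected to give about 100000 nM in this assay, within a range from 30000 nM to 300000 nM, most likely again reported as a limit.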

Compound 4, half-maximal cytotoxic concentration: > 100000 nM
Compound 4: a limit, no number (the forecaster's own chance of this, stated with the estimate: 65%); the middle value sits exactly at the limit.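

In this assay, within the data shown here, compound 1 and compound 4 both return only a limit, so no step between them can be read. The compounds shown leave open how far either compound lies from that limit, and whether 1,3-thiazol-2-yl in place of 3-fluorophenyl on an aromatic nitrogen changes the read-out at all.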